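This account rests on a few compounds, and the source may have more. Where it says the series, first, only, none or still open, it means among the compounds named here.

Three compounds built on the shared core differ only in the aryl ring at the far end of the molecule. Compound 1 `Nc1nc(N)c2cc(CSC(=S)N3CCN(c4ccc(Cl)c(Cl)c4)CC3)ccc2n1` carries a dichlorophenyl ring; in a functional assay on HCT-116 cells (Homo sapiens) for antiproliferative activity, read by MTT assay, with a stated time of 72 h (on this read-out lower numbers stand for stronger inhibition and higher numbers for weaker inhibition), compound 1 gives 6680 nM. Compound 2 `Nc1nc(N)c2cc(CSC(=S)N3CCN(c4ccccc4F)CC3)ccc2n1` carries a fluorophenyl ring instead, but in this assay compound 2 gives "not determined" (no result reported): the measurement was not made, so there is no number on which to place it, and compound 1 alone sets the level for this small series. Compound 3 `Nc1nc(N)c2cc(CSC(=S)N3CCN(c4ccccc4[N+](=O)[O-])CC3)ccc2n1` is compound 2 with one change: nitro in place of fluoro on an aromatic carbon. Among the compounds with values here, with no measured step to compare against, the expectation rests on compound 1, whose value of 6680 nM in this assay lies at the weak end of what such a cell assay can register. A step of this kind, swapping one small substituent for another on the same aryl ring, is expected to move the read-out only modestly, within or barely beyond the usual scatter, with no clear direction. Compound 3 is therefore estimated at 8000 nM in this assay, with a range from 2500 nM to 25000 nM.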

Compound 3, half-maximal inhibitory concentration: 5520 nM
Compound 3: middle estimate off by 1.4-fold (0.16 log units), on the high side; the measured number falls inside the stated range.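

In this assay the aryl ring at the far end of the molecule now has a second reading, a 1.2-fold lower number from compound 1 to compound 3 (0.08 log units; within the scatter) and so 2-nitrophenyl and 3,4-dichlorophenyl on the ring nitrogen cannot be told apart on this read-out. A single measured compound could not show this: two aryl rings with quite different substituents give readings that match within the usual scatter, although the claim holds for these two compounds only. Within the data shown here, the direct swap of fluoro for nitro on the ring still cannot be read: in this assay compound 2 has no number, so the one-place change that links it to compound 3 gives no step.

No measurement at hand bears on why these two rings read alike. Still open, going by these compounds, is whether a plain phenyl ring, or an amine or a carboxylic acid in place of the nitro group, would keep the number at this level or move it beyond the scatter, and whether changing the shared core or its link to the far ring would matter more than changing the ring.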